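A few compounds are considered here, and "the series" means these few. Any claim that something is new, unique, unknown or untested is made for them only; others in the source may bear on it.

Working notes on the acylguanidine series in a functional assay on U-373MG ATCC cells for inhibition, with U373 MG (Homo sapiens) as the target, read by MTT assay, with a stated time of 72 h; on this read-out lower numbers stand for stronger inhibition of growth and higher numbers for weaker inhibition of growth.

Compound 1 `CC(C)=CCC/C(C)=C/CC/C(C)=C/C(=O)NC(=N)N` gives 21000 nM in this assay. Compound 2 `CC(C)=CCC/C(C)=C/CC/C(C)=C/C(=O)NC(=N)NC(=O)C=C(C)C` gives 15700 nM, and compound 3 `CC(C)=CC(=O)NC(=N)NC(=O)C=C(C)C` gives 45600 nM. Among these numbers compound 1 stands second highest; its nearest neighbour is compound 2 and its furthest is compound 3, the latter lying beyond the scatter. For the measured compounds named here, the single measured step, a 1.3-fold lower number from compound 1 to compound 2 (0.13 log units; within the scatter), lies within the scatter.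

Compound 4 `CC(C)=CCC/C(C)=C/C(=O)NC(=N)N` has not yet been measured in this assay. Relative to compound 1 the change is hydrogen in place of 3-methylbut-2-en-1-yl on a saturated chain carbon bound to a double-bonded chain carbon. Going by the values given here, no measured step bears directly on it: the step from compound 1 to compound 2 alters only the amine nitrogen, and the pair compound 2 and compound 3 differs in both acyl chains at once, so only their two values can be read, which show a higher number with the shorter chains. On that basis a modest step toward a higher number is expected, a 1.4-fold higher number from compound 1 to compound 4 (0.15 log units; within the scatter), with wide uncertainty. For compound 4 the expected value is 30000 nM, in the range 14000 nM to 65000 nM.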

Compound 4, concentration for 50% growth inhibition: 46000 nM
Beside the measured number, compound 4's estimate is 1.5-fold (0.19 log units) below it; the range from low to high includes it.
By their numbers in this assay, from the lowest: compounds 2 and 1 (each within the scatter of the next); then compounds 3 and 4 (each within the scatter of the next).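

Hydrogen in place of 3-methylbut-2-en-1-yl on a saturated chain carbon bound to a double-bonded chain carbon gives a 2.2-fold higher number from compound 1 to compound 4 (0.34 log units; beyond the scatter) in this assay, the first step in this series to lie beyond the scatter. The number therefore responds to a change at this chain position, whereas the step on the amine nitrogen, a 1.3-fold lower number from compound 1 to compound 2 (0.13 log units; within the scatter), stays within the scatter and shows no such response. No available evidence accounts for the size or direction of the step at this position.

From the compounds shown here alone, whether a longer chain, an amine or a carboxylic acid at this position would give a lower or higher number remains open. Also open, going by these compounds, is whether (2-methylprop-1-en-1-yl)carbonyl on the amine nitrogen of compound 4 would change its number.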